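Chloro for allyloxy on the cyclopentenone series

This account rests on a few compounds, and the source may have more. Where it says the series, first, only, none or still open, it means among the compounds named here.

Compound 1, `COc1ccc(C2=C(c3cc(OC)c(OC)c(OC)c3)C(=O)C(O[SiH2]C(C)(C)C)C2)cc1OC(C)C`, gives 7.1 ug/mL in an ADME assay on PA-1 cells (Homo sapiens) for cytotoxicity, read by MTT assay, with a stated time of 72 h; on this read-out lower numbers stand for stronger inhibition and higher numbers for weaker inhibition. Compound 2, `C=CCOc1cc(C2=C(c3cc(OC)c(OC)c(OC)c3)C(=O)C(O)C2)ccc1OC`, carries a free hydroxyl on the shared core and an allyloxy group in place of the isopropoxy group of compound 1. For compound 2 this assay reports only a limit, > 100 ug/mL, which is where it stands among the two values shown, at the limit of > 100 ug/mL in this assay, at which 1 of the 2 values shown sits. Compounds 1 and 2 differ in more than one place, so their values are set side by side without a step between them.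

Compound 3, `COc1ccc(C2=C(c3cc(OC)c(OC)c(OC)c3)C(=O)C(O)C2)cc1Cl`, is not yet measured. It differs from compound 2 by chloro in place of allyloxy on an aromatic carbon. Within the data shown here, no measured step of this kind exists, so the expectation rests on compound 2 alone, whose reading is a limit, and on the single number given by compound 1. From compound 2 to compound 3 a gain is expected, an at least 2.5-fold lower number from compound 2 to compound 3 (0.39 log units; beyond the scatter), though uncertain in size. For compound 3 the estimate is 40 ug/mL, expected to fall between 6 ug/mL and 100 ug/mL.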

Compound 3, half-maximal inhibitory concentration: > 100 ug/mL
Compound 3 ended at the assay's limit; the forecaster's own chance of this, stated with the estimate: 40%; at least 2.5-fold (0.39 log units) between middle value and limit.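

Compound 2 and compound 3 both stop at the assay's limit in this assay, so no size can be read for chloro in place of allyloxy on an aromatic carbon: the limit of > 100 ug/mL in this assay, at which 2 of the 3 values shown sit.

The compounds shown leave open whether chloro or allyloxy gives the lower number on the shared core with its free hydroxyl.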